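Ethoxy to methoxy on the biaryl arm: compound 4

The source may report more compounds than this note shows. Statements on the series, on what has been measured and on what is new or still open speak of the compounds shown alone.

Three compounds of the shared core have numbers in an assay on isolated protein for agonist activity at Bile acid receptor (Homo sapiens), read by AlphaScreen, with a stated time of 30 min; on this read-out higher numbers stand for larger maximal responses and lower numbers for smaller maximal responses. Compound 1 `CCOc1cccc(-c2ccc([C@H]3S[C@@H](C)C(=O)Nc4c3c(C)nn4-c3ccccc3C)cc2)c1` gives 13% and stands lowest of the three. Compound 2 `Cc1nn(-c2ccccc2I)c2c1C(c1ccc(Oc3ccccc3)cc1)SC(C)C(=O)N2` gives 130%, a number beyond the scatter above compound 1. Compound 3 `CCCc1ccccc1-n1nc(C)c2c1NC(=O)[C@H](C)S[C@@H]2c1ccc(Oc2ccccc2)cc1` gives 240%, further above compound 1 and also beyond the scatter. Within the data shown here, compounds 2 and 3 carry a phenoxy group where compound 1 carries a 3-ethoxyphenyl, and they differ from compound 1 in more than one place, so no single step between measured compounds can be isolated from these three.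

Compound 4 `COc1cccc(-c2ccc([C@H]3S[C@@H](C)C(=O)Nc4c3c(C)nn4-c3ccccc3C)cc2)c1` is not yet measured in this assay. It differs from compound 1 in one place: hydrogen in place of methyl on a saturated chain carbon bound to an oxygen on an aromatic ring Read one bond further out, the change is ethyl to methyl, ethoxy to methoxy, 3-ethoxyphenyl to 3-methoxyphenyl. Among the measured compounds shown here, no measured pair shows this change on this core, so the step has to be estimated from the change alone. Given that only a methyl leaves and a hydrogen enters, the expected step of a number 2 percentage points higher from compound 1 to compound 4 (within the scatter) is small and is not expected to exceed the scatter in either direction. Compound 4 is therefore estimated at 15%, within a range from 5% to 40%.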

Compound 4, largest response reached (reported as efficacy), in percent of the reference or control that the assay uses: 41%
Compound 4: the middle estimate sits 26 percentage points below what was measured; the measured number lies above the stated range.
By their numbers in this assay, from the lowest: compound 1; then compound 4; then compound 2; then compound 3.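

Shortening ethoxy to methoxy, with a methyl leaving and a hydrogen entering on a saturated chain carbon bound to an oxygen on an aromatic ring, gives the only single-place step in the series so far: in this assay the change reads (a number 28 percentage points higher from compound 1 to compound 4 (beyond the scatter)). This position is therefore not indifferent to the loss of one methyl, and within this one pair the methoxy compound has the larger maximal response, so a change of a single carbon on this chain is enough to move the number beyond the scatter. The data shown offer nothing that accounts for the direction or size of this step.

Among these compounds, with only two chain lengths on this core, it remains open whether the number would climb further with a free hydroxy group, or how a propoxy chain or an amine at this place would read. From the compounds shown here alone, it also remains open whether the step keeps its size with other groups on the shared core, as compound 2 and compound 3 differ from compound 1 in more than one place and give no second reading of this change.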